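Swapping chloro for trifluoromethyl on the aniline of compound 3

A few compounds are considered here, and "the series" means these few. Any claim that something is new, unique, unknown or untested is made for them only; others in the source may bear on it.

Compound 3 `FC(F)(F)c1ccc(CSc2nc(Nc3ccc(Cl)cc3)c3ccccc3n2)cc1` gives 16800 nM in a functional assay on MGC-803 cells (Homo sapiens) for cytotoxicity, read by MTT assay, with a stated time of 72 h; a lower number here means a stronger inhibitor, a higher number a weaker inhibitor. Compound 1 `CCCCCCCCNc1nc(SCc2ccc(C(F)(F)F)cc2)nc2ccccc12` gives 12600 nM in this assay, so the two sit within the usual scatter of each other. Compound 2 `FC(F)(F)c1ccc(CSc2nc(Nc3ccccc3C(F)(F)F)c3ccccc3n2)cc1` reaches only a limit of this assay, > 50000 nM. The steps of a 1.3-fold higher number from compound 1 to compound 3 (0.12 log units; within the scatter) and an at least 2.9-fold lower number from compound 2 to compound 3 (0.47 log units; beyond the scatter) show that a 4-chlorophenyl group on the ring nitrogen is tolerated about as well as octyl and better than 2-(trifluoromethyl)phenyl. Compound 4 `FC(F)(F)c1ccc(CSc2nc(Nc3ccc(C(F)(F)F)cc3)c3ccccc3n2)cc1` differs from compound 3 by trifluoromethyl in place of chloro on an aromatic carbon. Going by the values given here, no measured step covers this exact swap; the nearest, a 1.3-fold higher number from compound 1 to compound 3 (0.12 log units; within the scatter), was within the scatter, so little change beyond the scatter is expected, a 1.1-fold higher number from compound 3 to compound 4 (0.03 log units; within the scatter). Compound 4 is therefore estimated at 18000 nM, between 8000 nM and 45000 nM.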

Compound 4, half-maximal inhibitory concentration: 6170 nM
Estimate against measurement, compound 4: 2.9-fold (0.46 log units) above; the whole stated range lies above it.
By their numbers in this assay, from the lowest: compound 4; then compounds 1 and 3 (each within the scatter of the next). At a limit, above all of these: compound 2.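

Trifluoromethyl in place of chloro gives a 2.7-fold lower number from compound 3 to compound 4 (0.44 log units; beyond the scatter), showing that the number responds to the group on this aromatic carbon. Moving from 2-(trifluoromethyl)phenyl to 4-(trifluoromethyl)phenyl gives an at least 8.1-fold lower number from compound 2 to compound 4 (0.90 log units; beyond the scatter), and 4-(trifluoromethyl)phenyl in place of octyl gives a 2.0-fold lower number from compound 1 to compound 4 (0.31 log units; beyond the scatter), making it the only aromatic group shown to pass octyl beyond the scatter. Compound 2 stands at a limit, not a number, and its step is only a bound: the limit of > 50000 nM in this assay, at which 1 of the 4 values shown sits.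

Going by these compounds, what remains open is how a methoxy group, an amine or a carboxylic acid on this aromatic carbon would compare with chloro and trifluoromethyl.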